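Removing bromine from a bromo isatin and its imino analogue

A few compounds are considered here, and "the series" means these few. Any claim that something is new, unique, unknown or untested is made for them only; others in the source may bear on it.

Compound 1 `Cc1ccc2nc(/N=C3\C(=O)N(CN(C)C)c4cccc(Br)c43)sc2c1` and compound 3 `Cc1ccc2nc(/N=C3\C(=O)N(CN(C)C)c4ccccc43)sc2c1` differ by one change: hydrogen in place of bromo on an aromatic carbon. In a functional assay on MDA-MB-468 cells (Homo sapiens) for cytotoxicity, read by sulforhodamine B assay, with a stated time of 48 h (on this read-out lower numbers stand for stronger inhibition of growth and higher numbers for weaker inhibition of growth), compound 1 gives 27400 nM, and compound 3 gives 35500 nM; the step of a 1.3-fold higher number from compound 1 to compound 3 (0.11 log units; within the scatter) is the only measured instance of this change among the compounds shown. Compound 2 `CN(C)CN1C(=O)C(=O)c2c(Br)cccc21` has a different core; how its core differs from that of compound 1 is not broken down here. In this assay compound 2 gives 49000 nM, a number whose distance from compound 3 and from compound 1 stays within the scatter. Compound 4 `CN(C)CN1C(=O)C(=O)c2ccccc21` is the analogue of compound 2 carrying the same change, (hydrogen in place of bromo on an aromatic carbon), at the same place. The expectation for compound 4 rests on the measured step from compound 1 to compound 3, and the estimated step of a 1.3-fold higher number from compound 2 to compound 4 (0.10 log units; within the scatter) is taken to be of that same small size. In this assay compound 4 is therefore expected to give about 62000 nM, within a range from 30000 nM to 130000 nM.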

Compound 4, concentration for 50% growth inhibition: 50200 nM
Compound 4: middle estimate off by 1.2-fold (0.09 log units), on the high side, and the stated range covers the measured number.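

In this assay, among these compounds, hydrogen in place of bromo gives a 1.0-fold higher number from compound 2 to compound 4 (0.01 log units; within the scatter), so on the core of compound 2, as on the core of compound 1, this change produces no step that can be told from the scatter. Set side by side, the two steps agree, and in this series the change carries from one core to the other as a step too small to read: the same change on two cores in this assay, a 1.3-fold higher number (0.11 log units; within the scatter) from compound 1 to compound 3 and a 1.0-fold higher number (0.01 log units; within the scatter) from compound 2 to compound 4, 1.3-fold (0.10 log units) apart, within the scatter of two such steps This does not show that the same would hold on any further core, as the comparison rests on only two pairs, and it gives no size for the change beyond saying that both steps are small.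

As far as these compounds go, whether fluoro, chloro or methoxy at that same place would give a step beyond the scatter stays open. So does whether the result would hold with a longer chain or a carboxylic acid in place of the dimethylaminomethyl group.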